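The source may hold more compounds than are shown below. What is called first, only, known or untested is meant among the compounds shown, and "the series" means these compounds.

Values so far in a functional assay on CWR22R cells (Homo sapiens) for antiproliferative activity, read by propidium iodide staining, with a stated time of 96 h; a lower number here means a stronger inhibitor, a higher number a weaker inhibitor:
compound 1 `CC(O)(CSc1cccc(S(F)(F)(F)(F)F)c1)C(=O)Nc1ccc([N+](=O)[O-])cc1C(F)(F)F` 17500 nM
compound 2 `CC(O)(CS(=O)(=O)c1ccc(S(F)(F)(F)(F)F)cc1)C(=O)Nc1cccc(S(F)(F)(F)(F)F)c1` 12300 nM
compound 3 `CC(O)(CS(=O)(=O)c1ccc(F)cc1)C(=O)Nc1cccc(S(F)(F)(F)(F)F)c1` 38900 nM

Compound 3 (38900 nM) carries the highest number of the three and is the weakest of this small set. The value nearest to it belongs to compound 1 (17500 nM), and the furthest belongs to compound 2 (12300 nM). The next compound is compound 4 `CC(O)(CS(=O)(=O)c1ccccc1OC(F)(F)F)C(=O)Nc1cccc(S(F)(F)(F)(F)F)c1`, in which 2-(trifluoromethoxy)phenyl stands in place of 4-fluorophenyl on a sulfonyl sulfur (2-(trifluoromethoxy)phenyl in place of 4-fluorophenyl on a sulfonyl sulfur).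

Within the data shown here, only one measured step bears on this change: a 3.2-fold higher number from compound 2 to compound 3 (0.50 log units; beyond the scatter). It also alters the aromatic group on the sulfonyl sulfur, with a fluorine atom taking the place of a larger group. Read in reverse, the larger group goes with the lower number. Among the measured compounds shown here, no measured compound carries a 2-(trifluoromethoxy)phenyl group, so this single step is limited guidance. A small move toward a lower number is therefore expected in this assay, possibly no larger than the scatter. The expected change is a 1.9-fold lower number from compound 3 to compound 4 (0.29 log units; within the scatter) in this estimate. Compound 4 is estimated at 20000 nM with an expected range of 8000 nM to 50000 nM in this assay here.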

Compound 4, half-maximal inhibitory concentration: 17100 nM
Compound 4: middle estimate off by 1.2-fold (0.07 log units), on the high side, within the range that was stated.
By their numbers in this assay, from the lowest: compounds 2, 4 and 1 (each within the scatter of the next); then compound 3.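

In this assay, among these compounds, the change on the sulfonyl sulfur gives a 2.3-fold lower number from compound 3 to compound 4 (0.36 log units; beyond the scatter), so a second aromatic group now goes with a lower number than 4-fluorophenyl, alongside the one carried by compound 2. Among the compounds shown here, compound 2 at 12300 nM and compound 4 at 17100 nM lie within the scatter of each other, although the two groups on the sulfonyl sulfur are different, and so far 4-fluorophenyl is the only group here that stands apart from the others. The data offer no measurement that accounts for this step, which therefore stands as an observation only.

The compounds shown leave open whether an unsubstituted phenyl, or a phenyl ring carrying an amine, a nitrile or a carboxylic acid, would fall with compound 3 or with compound 2 and compound 4. They also leave open whether a pyridine ring on the sulfonyl sulfur would keep this lower number, and whether the same step would hold on a core carrying a different amide group, such as that of compound 1.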